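Adding a Carbamoyl Group to Compound 2

The source may report more compounds than this note shows. Statements on the series, on what has been measured and on what is new or still open speak of the compounds shown alone.

In a functional assay on HepG2 cells (Homo sapiens) for cytotoxicity, read by MTT assay, with a stated time of 48 h (a lower number here means a stronger inhibitor, a higher number a weaker inhibitor), compound 2 `Cc1n[nH]c2c1C(c1ccc(N(C)C)cc1)C=C(N)N2` gives 20600 nM and compound 1 `Cc1n[nH]c2c1C(c1ccc(N(C)C)cc1)C(C(=O)N/N=C/c1ccc(Cl)cc1)=C(N)N2` gives 39500 nM. Only these two numbers are available, and they lie within the usual scatter of each other, so neither compound stands apart. Compound 3 `Cc1n[nH]c2c1C(c1ccc(N(C)C)cc1)C(C(N)=O)=C(N)N2` differs from compound 2 by carbamoyl in place of hydrogen on a double-bonded ring carbon. Among the measured compounds shown here, no measured pair isolates a single structural change, so the data give no direct measure of this one. The expectation therefore rests on the narrow span of the two known values. In this assay, the estimated 1.5-fold higher number from compound 2 to compound 3 (0.16 log units; within the scatter) is expected to stay within the scatter, with no clear direction. For compound 3, the expected value is 30000 nM, with an estimated range of 12000 nM to 75000 nM.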

Compound 3, half-maximal inhibitory concentration: 5280 nM
Estimate against measurement, compound 3: 5.7-fold (0.75 log units) above; measured number outside the range, below it.
By their numbers in this assay, from the lowest: compound 3; then compounds 2 and 1 (each within the scatter of the next).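

In this assay, carbamoyl in place of hydrogen on the double-bonded ring carbon gives a 3.9-fold lower number from compound 2 to compound 3 (0.59 log units; beyond the scatter), which shows that this position responds to substitution, something the two earlier values could not show. The change also depends on what the carbamoyl carries: a hydrogen atom in place of the group of 9 heavy atoms on the amide-type nitrogen gives a 7.5-fold lower number from compound 1 to compound 3 (0.87 log units; beyond the scatter), so the lower number belongs to the unsubstituted carbamoyl and not to every group built on it. Nothing available here explains either step.

From the compounds shown here alone, whether an amine, a carboxylic acid or a methyl ester at this ring carbon would behave like carbamoyl remains open. So does the effect of a single methyl group on the amide-type nitrogen, which would show how much of that group's effect a far smaller substituent reproduces.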